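Swapping the aryl group on a shared core

A few compounds are considered here, and "the series" means these few. Any claim that something is new, unique, unknown or untested is made for them only; others in the source may bear on it.

Measured in a functional assay on DU-145 cells (Homo sapiens) for inhibition, read by trypan blue exclusion, with a stated time of 96 h; on this read-out higher numbers stand for weaker inhibition of growth and lower numbers for stronger inhibition of growth:
- compound 1 `Cc1ccsc1/C=C(/SCc1ccc(Cl)cc1)C(=O)c1ccc(Cl)cc1`: 50000 nM
- compound 2 `O=C(/C(=C\c1ccc(O)c([N+](=O)[O-])c1)SCc1ccc(Cl)cc1)c1ccc(Cl)cc1`: 10000 nM
- compound 3 `COc1ccccc1/C=C(/SCc1ccc(Cl)cc1)C(=O)c1ccc(Cl)cc1`: 1000 nM

The three compounds differ only on a double-bonded chain carbon bound to a double-bonded chain carbon, and each exchange there has moved the number beyond the scatter. The measured steps are a 5.0-fold lower number from compound 1 to compound 2 (0.70 log units; beyond the scatter), a 10-fold lower number from compound 2 to compound 3 (1.00 log units; beyond the scatter) and a 50-fold lower number from compound 1 to compound 3 (1.70 log units; beyond the scatter). Compound 3 therefore holds the lowest number of the three, and compound 2 is its nearest neighbour.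

The next compound, compound 4 `O=C(/C(=C\c1ccc(Br)cc1)SCc1ccc(Cl)cc1)c1ccc(Cl)cc1`, has 4-bromophenyl in place of 2-methoxyphenyl at that same place (4-bromophenyl in place of 2-methoxyphenyl on a double-bonded chain carbon bound to a double-bonded chain carbon). Within the data shown here, no measured step makes this exact exchange, so the three steps offer only a guide to its size. Both exchanges away from the 2-methoxyphenyl group gave higher numbers, so a modest rise in this assay seems more likely than a fall. The expected step is a 3.0-fold higher number from compound 3 to compound 4 (0.48 log units; beyond the scatter). For compound 4 the estimated value is 3000 nM, with an expected range from 500 nM to 15000 nM.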

Compound 4, concentration for 50% growth inhibition: 1000 nM
For compound 4 the middle estimate is 3.0-fold (0.48 log units) above the measured one; measured number inside the range.
By their numbers in this assay, from the lowest: compounds 3 and 4 (each within the scatter of the next); then compound 2; then compound 1.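

In this assay, among these compounds, the 2-methoxyphenyl group proves not to be the only group that reaches the low end of this series: placing 4-bromophenyl on the same double-bonded chain carbon gives no change at the digits printed from compound 3 to compound 4 (within the scatter), even though the entering group has bromine instead of oxygen and no hydrogen-bond acceptor. The 4-bromophenyl group also shows a 10-fold lower number from compound 2 to compound 4 (1.00 log units; beyond the scatter) and a 50-fold lower number from compound 1 to compound 4 (1.70 log units; beyond the scatter), so two differently substituted phenyl groups now stand apart from the 4-hydroxy-3-nitrophenyl and 3-methylthiophen-2-yl groups. No evidence is available to explain this match.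

The compounds shown leave open whether an unsubstituted phenyl group would give a similar number at this place. They also do not show how a phenyl group carrying an amine or a carboxylic acid would behave there.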